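The source may hold more compounds than are shown below. What is called first, only, known or untested is meant among the compounds shown, and "the series" means these compounds.

Compound 3 `CCOC(=O)CO/N=C(/c1ccc(OC)c(OC)c1OC)c1cccc2ccccc12` belongs to a small set of oxime ethers and esters built on a shared core, and its standing in a functional assay on MCF7 cells (Homo sapiens) for inhibition, read by sulforhodamine B assay, with a stated time of 48 h (on this read-out lower numbers stand for stronger inhibition and higher numbers for weaker inhibition), is known only as a limit, since compound 3 gives > 20000 nM. Compound 1 `CCOC(=O)CCO/N=C(/c1ccc(OC)c(OC)c1OC)c1cccc2ccccc12` is reported at the same kind of limit, with > 20000 nM. Compound 2 `COc1ccc(/C(=N/OC(C)=O)c2cccc3ccccc23)c(OC)c1OC` likewise reaches only a limit, at > 20000 nM. The steps among them, a step that the two limits leave unreadable from compound 1 to compound 2, a step that the two limits leave unreadable from compound 1 to compound 3 and a step that the two limits leave unreadable from compound 2 to compound 3, therefore carry no readable size, and the limit of > 20000 nM in this assay, at which 3 of the 3 values shown sit, sums up the whole set so far.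

Compound 4 `COc1ccc(/C(=N/OCC(=O)O)c2cccc3ccccc23)c(OC)c1OC` is the next member, differing from compound 3 by hydrogen in place of ethyl on an oxygen next to a carbonyl group. Going by the values given here, none of the measured steps gives a direction for this change, as every one of them joins two limits. The step from compound 3 to compound 4 is accordingly expected to be a step that the limit leaves unreadable from compound 3 to compound 4, with no grounds for a change beyond the scatter. In this assay compound 4 is estimated at 30000 nM, within a range from 10000 nM to 100000 nM, and it would most likely again be reported only as a limit.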

Compound 4, half-maximal inhibitory concentration: > 20000 nM
Compound 4: only a limit was reported (the forecaster's own chance of this, stated with the estimate: 80%); the middle value lies beyond the limit too.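

Going by these compounds alone, compound 4 is again reported only as a limit, so no step joining it to compound 1, compound 2 or compound 3 can be read: the limit of > 20000 nM in this assay, at which 4 of the 4 values shown sit. The compounds shown leave open whether any of the four truly differs from the others in this assay.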